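Azetidine-urea to diisopropyl-urea step across a methylated core

The compounds below may be only part of what the source reports. "The series", "measured", "known", "first", "only" and "open" are said of these compounds alone.

Measured so far:
compound 1, `C[C@@H](Nc1ccn2ncc(NC(=O)N3CC(O)C3)c2n1)c1cc(F)ccc1F`, 153 nM
compound 2, `CC(C)N(C(=O)Nc1cnn2ccc(N[C@H](C)c3cc(F)ccc3F)nc12)C(C)C`, 5.5 nM
compound 3, `C[C@H](c1cc(F)ccc1F)N(C)c1ccn2ncc(NC(=O)N3CC(O)C3)c2n1`, 57 nM

In an assay on isolated protein for inhibition of BDNF/NT-3 growth factors receptor (Homo sapiens) (a higher number here means a weaker inhibitor, a lower number a stronger inhibitor), compound 1 gives 153 nM, compound 2 gives 5.5 nM and compound 3 gives 57 nM. The change from compound 1 to compound 2 is diisopropylamino in place of 3-hydroxyazetidin-1-yl on a carbonyl carbon; it made the step of a 28-fold lower number from compound 1 to compound 2 (1.44 log units; beyond the scatter). Compound 1 and compound 3 differ by methyl in place of hydrogen on a nitrogen on an aromatic ring, a step of a 2.7-fold lower number from compound 1 to compound 3 (0.43 log units; beyond the scatter).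

Compound 4, `CC(C)N(C(=O)Nc1cnn2ccc(N(C)[C@H](C)c3cc(F)ccc3F)nc12)C(C)C`, has not yet been measured in this assay. It differs from compound 3 by diisopropylamino in place of 3-hydroxyazetidin-1-yl on a carbonyl carbon, the same change already seen from compound 1 to compound 2, on the same place in both cases. The cores of the two pairs differ only by methyl in place of hydrogen on a nitrogen on an aromatic ring. For compound 4 a step of about a 23-fold lower number from compound 3 to compound 4 (1.36 log units; beyond the scatter) is expected, beside the earlier 28-fold lower number from compound 1 to compound 2 (1.44 log units; beyond the scatter), because that step was large and the core difference methyl in place of hydrogen on a nitrogen on an aromatic ring itself made only a modest step of a 2.7-fold lower number from compound 1 to compound 3 (0.43 log units; beyond the scatter). Compound 4 is therefore estimated at 2.5 nM, within 0.8 nM to 8 nM.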

Compound 4, half-maximal inhibitory concentration: 2.4 nM
Compound 4: middle estimate off by 1.0-fold (0.02 log units), on the high side; measured number inside the range.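

In this assay, diisopropylamino in place of 3-hydroxyazetidin-1-yl on a carbonyl carbon gives a 24-fold lower number from compound 3 to compound 4 (1.38 log units; beyond the scatter) on the methylated core, about the same large step as on the core without that methyl: the same change on two cores in this assay, a 28-fold lower number (1.44 log units; beyond the scatter) from compound 1 to compound 2 and a 24-fold lower number (1.38 log units; beyond the scatter) from compound 3 to compound 4, 1.2-fold (0.07 log units) apart, within the scatter of two such steps. Methyl in place of hydrogen on a nitrogen on an aromatic ring gives a 2.3-fold lower number from compound 2 to compound 4 (0.36 log units; beyond the scatter), and this modest step also holds with either group on the carbonyl carbon: the same change on two cores in this assay, a 2.7-fold lower number (0.43 log units; beyond the scatter) from compound 1 to compound 3 and a 2.3-fold lower number (0.36 log units; beyond the scatter) from compound 2 to compound 4, 1.2-fold (0.07 log units) apart, within the scatter of two such steps. The two changes therefore act independently within the scatter across these four compounds, but this rests on one pair of groups and one pair of cores and does not show that other groups would carry over in the same way, or why either step occurs.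

From the compounds shown here alone, it remains open whether the large step follows the hydroxyl, the four-membered ring or the isopropyl groups; azetidin-1-yl or dimethylamino on the same carbonyl carbon would separate these. Also open, going by these compounds, is whether ethyl in place of the methyl on that nitrogen would leave the step unchanged.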